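Swapping the ring on the branching carbon of compound 1

The compounds below may be only part of what the source reports. "The series", "measured", "known", "first", "only" and "open" are said of these compounds alone.

In an ADME assay on MDCK cells (Canis lupus familiaris) for permeability, in the apical to basolateral direction (a lower number here means that the compound crosses the layer more slowly, a higher number that the compound crosses the layer faster), compound 1, with structure `CC(C)C(/C=C1\NC(=O)NC1=O)c1ccc(-c2ccc3cccc(F)c3c2)[nH]c1=O`, gives 12.3 10^-6 cm/s. Among the compounds with values here, this is the higher of the two numbers measured so far. Compound 2, with structure `CC(C)[C@@H](c1ccc(-c2ccc3cccc(F)c3c2)[nH]c1=O)[C@@H]1OC(=O)NC1=O`, gives 3.15 10^-6 cm/s in this assay, a gap that lies beyond the usual scatter.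

Compound 3, with structure `CC(C)C(c1ccc(-c2ccc3cccc(F)c3c2)[nH]c1=O)C1SC(=O)NC1=O`, has not yet been measured. It differs from compound 1 in one place: a group of 7 heavy atoms (3 carbon, 1 nitrogen, 2 oxygen, 1 sulfur; one five-membered non-aromatic ring with 2 hetero atoms) in place of a group of 8 heavy atoms (4 carbon, 2 nitrogen, 2 oxygen; one five-membered non-aromatic ring with 2 hetero atoms), on a saturated chain carbon bound to an aromatic carbon and a saturated chain carbon. Within the data shown here, no measured pair shows exactly this change, so the step can only be guessed from the compounds at hand. Because compound 2 gives 3.15 10^-6 cm/s in this assay, a move downward from compound 1 is expected, and the step from compound 1 to compound 3 in this assay is estimated at a 2.5-fold lower number from compound 1 to compound 3 (0.39 log units; beyond the scatter), beyond the scatter. Compound 3 is therefore expected to give about 5 10^-6 cm/s in this assay, within a range from 2.5 10^-6 cm/s to 10 10^-6 cm/s.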

Compound 3, apparent permeability: 26.3 10^-6 cm/s
Beside the measured number, compound 3's estimate is 5.3-fold (0.72 log units) below it; the measured number lies above the stated range.
By their numbers in this assay, from the lowest: compound 2; then compound 1; then compound 3.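

With 2,4-dioxo-1,3-thiazolidin-5-yl on the saturated chain carbon, this assay shows a 2.1-fold higher number from compound 1 to compound 3 (0.33 log units; beyond the scatter) and gives the first one-place step measured here. The group on this carbon can therefore be exchanged with the number rising rather than falling, at least for this one pair. The step changes several counted features together, going from 2 hydrogen-bond donors to 1 and from 3 double bonds outside aromatic rings to 2, and nothing in hand ties the rise to any one of them.

One step cannot show whether the sulfur, the hydrogen-bond count or the other differences between the two groups set the number. From the compounds shown here alone, how an open-chain group on this carbon, such as a carboxylic acid or an amine, would behave also remains open.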